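Moving the chlorine from compound 2 to compound 3

The compounds below may be only part of what the source reports. "The series", "measured", "known", "first", "only" and "open" are said of these compounds alone.

Measured in a functional assay on HT-29 cells (Homo sapiens) for antiproliferative activity, read by sulforhodamine B assay, with a stated time of 48 h; a higher number here means a weaker inhibitor, a lower number a stronger inhibitor:
compound 1 `COc1ccccc1OS(=O)(=O)c1ccc(N2CCN(C)C2=O)cc1`: 26000 nM
compound 2 `CN1CCN(c2ccc(S(=O)(=O)Oc3cccc(Cl)c3)cc2)C1=O`: 2100 nM

Of the two measured compounds, compound 2 holds the lower number at 2100 nM, which makes it the stronger inhibitor of the pair. The next compound is compound 3 `CN1CCN(c2ccc(S(=O)(=O)Oc3ccc(Cl)cc3)cc2)C1=O`, which keeps the shared core and differs from compound 2 in one place: 4-chlorophenyl in place of 3-chlorophenyl on an oxygen. In words, 4-chlorophenyl stands in place of 3-chlorophenyl on an oxygen, and the two compounds have the same atoms, joined differently.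

Going by the values given here, only one measured step bears on this change, and it bears only loosely. The large step of a 12-fold lower number from compound 1 to compound 2 (1.09 log units; beyond the scatter) shows that the group on this oxygen can matter, but it exchanged 2-methoxyphenyl for 3-chlorophenyl. Among the compounds with values here, no measured pair shows what moving the chlorine alone does, so the data give no direction. In this assay, the expectation is therefore a smaller change, probably none beyond the scatter. The expected step is a 1.1-fold lower number from compound 2 to compound 3 (0.02 log units; within the scatter). For compound 3 the estimated value is 2000 nM, with an expected range of 600 nM to 7000 nM.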

Compound 3, half-maximal inhibitory concentration: 12000 nM
Compound 3: middle estimate off by 6.0-fold (0.78 log units), on the low side; measured number outside the range, above it.
By their numbers in this assay, from the lowest: compound 2; then compound 3; then compound 1.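

In this assay the place of the chlorine on the ring carried by the oxygen matters in its own right: the measurements give a 5.7-fold higher number from compound 2 to compound 3 (0.76 log units; beyond the scatter) even though the two compounds have the same atoms, so 3-chlorophenyl and 4-chlorophenyl are not interchangeable at this position. The gain over 2-methoxyphenyl also depends on where the chlorine sits, with a 2.2-fold lower number from compound 1 to compound 3 (0.34 log units; beyond the scatter) for 4-chlorophenyl against a 12-fold lower number from compound 1 to compound 2 (1.09 log units; beyond the scatter) for 3-chlorophenyl. Nothing available here accounts for this difference between the two chlorophenyl groups.

The compounds shown do not separate the identity of the substituent from its place on the ring, since the methoxy group and the chlorine have not been compared at the same place; 3-methoxyphenyl or 3-bromophenyl would bear directly on that question. As far as these compounds go, it also remains open whether the trend from 3-chlorophenyl to 4-chlorophenyl holds for other groups on this ring, such as an amine or a carboxylic acid, or whether it is particular to chlorine.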